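This account rests on a few compounds, and the source may have more. Where it says the series, first, only, none or still open, it means among the compounds named here.

Measured so far:
- compound 1, `O=C1Nc2ccc(S(=O)(=O)N3CCOCC3)cc2/C1=N/NS(=O)(=O)c1ccccc1`, with 23900 nM in a functional assay on HepG2 cells (Homo sapiens) for cytotoxicity, read by sulforhodamine B assay, with a stated time of 24 h; a lower number here means a stronger inhibitor, a higher number a weaker inhibitor
- compound 2, `O=C1Nc2ccc(S(=O)(=O)N3CCOCC3)cc2/C1=N/c1ccc(/N=C2\C(=O)Nc3ccc(S(=O)(=O)N4CCOCC4)cc32)cc1`, with 8840 nM in this assay

Of the two compounds measured, compound 1 has the higher number, so it is the weaker of the pair in this assay, and the gap to compound 2 lies beyond the usual scatter.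

Compound 3, `Cc1ccc(/N=C2\C(=O)Nc3ccc(S(=O)(=O)N4CCOCC4)cc32)cc1`, has not yet been measured. It differs from compound 1 in one place: 4-methylphenyl in place of (phenylsulfonyl)amino on a double-bonded nitrogen. With this change the double-bonded nitrogen carries a plain aromatic ring instead of a sulfonyl-bearing group, a pattern closer to what compound 2 shows, and compound 2 gives the lower number of the two measured.

Going by the values given here, no step between measured compounds is available to anchor the change directly. The step expected in this assay is a 2.0-fold lower number from compound 1 to compound 3 (0.30 log units; within the scatter), towards a lower number, of a size comparable to the gap between compound 1 and compound 2. Compound 3 is therefore estimated at 12000 nM, with a likely range from 4000 nM to 35000 nM.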

Compound 3, half-maximal inhibitory concentration: 12800 nM
The estimate for compound 3 lay 1.1-fold (0.03 log units) below the measured number; the measured number falls inside the stated range.
By their numbers in this assay, from the lowest: compounds 2, 3 and 1 (each within the scatter of the next, the first and the last beyond it).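

In this assay, placing 4-methylphenyl in place of (phenylsulfonyl)amino on the double-bonded nitrogen gives a 1.9-fold lower number from compound 1 to compound 3 (0.27 log units; within the scatter), so this pair cannot be told apart. The change is a large one in structure: the group that leaves has a sulfonyl unit, a hydrogen-bond donor and hydrogen-bond acceptors, while the group that enters has only carbon atoms and no donors or acceptors, yet the reading stays within repeat scatter. For this one pair, the sulfonyl-bearing group is therefore not needed to keep the number at this level, and nothing measured explains why.

Still open, going by these compounds, is whether any group at this place can shift the number beyond the scatter. An amine or a carboxylic acid in place of the methyl of 4-methylphenyl, or a longer alkyl chain there, would test this.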